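This account rests on a few compounds, and the source may have more. Where it says the series, first, only, none or still open, it means among the compounds named here.

Measured in an assay for inhibition of arginase-1 (Homo sapiens), read by colorimetric assay, with a stated time of 60 min, in the presence of a further agent that is not named here; on this read-out higher numbers stand for weaker inhibition and lower numbers for stronger inhibition:
compound 1 `N[C@@]1(C(=O)O)CN(C[C@@H]2COCCN2)C[C@@H]1CCCB(O)O`, 10 nM
compound 2 `Cc1[nH]ncc1CN1C[C@H](CCCB(O)O)[C@](N)(C(=O)O)C1`, 400 nM
compound 3 `N[C@@]1(C(=O)O)CN(Cc2ncccc2F)C[C@@H]1CCCB(O)O`, 670 nM

Compound 3 gives the highest number of the three; compound 2 sits within the scatter of it, while compound 1 lies far lower, as a 67-fold higher number from compound 1 to compound 3 (1.83 log units; beyond the scatter) shows. Compound 4 `C[C@H](N)CN1C[C@H](CCCB(O)O)[C@](N)(C(=O)O)C1` differs from compound 3 by 1-aminoethyl in place of 3-fluoropyridin-2-yl on a saturated chain carbon bound to an amine nitrogen in a ring. The step that bears on it is the exchange of the saturated ring carrying a hydrogen-bond donor for an aromatic group, a 67-fold higher number from compound 1 to compound 3 (1.83 log units; beyond the scatter), a large rise; a 1.7-fold higher number from compound 2 to compound 3 (0.22 log units; within the scatter) between the two aromatic groups was small. Compound 4 returns to a saturated group with a hydrogen-bond donor, so a large drop in this assay is expected, though the group is smaller than in compound 1 and need not reach it. Compound 4 is estimated at 50 nM, range 10 nM to 300 nM, a step of a 13-fold lower number from compound 3 to compound 4 (1.13 log units; beyond the scatter).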

Compound 4, half-maximal inhibitory concentration: 7.7 nM
Beside the measured number, compound 4's estimate is 6.5-fold (0.81 log units) above it; the measured number lies below the stated range.
By their numbers in this assay, from the lowest: compounds 4 and 1 (each within the scatter of the next); then compounds 2 and 3 (each within the scatter of the next).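

At this place, on a saturated chain carbon bound to an amine nitrogen in a ring, 1-aminoethyl gives an 87-fold lower number from compound 3 to compound 4 (1.94 log units; beyond the scatter) and a 52-fold lower number from compound 2 to compound 4 (1.72 log units; beyond the scatter) in this assay, so an aromatic ring is not needed for strong inhibition. The six-membered non-aromatic ring of compound 1 is not needed either: a 1.3-fold lower number from compound 1 to compound 4 (0.11 log units; within the scatter) leaves the two compounds within the scatter, with no ring in the entering group. No measurement shown accounts for these steps.

As far as these compounds go, whether the amine of 1-aminoethyl or its defined stereocentre matters remains open. So does the outcome with a hydroxyl in place of that amine, or with a longer aminoalkyl chain.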